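Aryl-triazole series: notes ahead of compound 3 cytotoxicity

This account rests on a few compounds, and the source may have more. Where it says the series, first, only, none or still open, it means among the compounds named here.

Measured so far:
Compound 1, `CCCC[C@@H](CCn1cncn1)c1ccc(Cl)cc1`: 18.7 ug/mL
Compound 2, `CCCC[C@@H](CCn1cncn1)c1ccc(C)cc1`: 56.5 ug/mL

In an ADME assay on RD cells (Homo sapiens) for cytotoxicity, read by MTT assay, with a stated time of 3 days (on this read-out lower numbers stand for higher toxicity in this test and higher numbers for lower toxicity in this test), compound 2 gives 56.5 ug/mL, the higher of the two numbers in hand; compound 1 gives 18.7 ug/mL. Going by the values given here, the single measured step, a 3.0-fold higher number from compound 1 to compound 2 (0.48 log units; beyond the scatter), concerns only the aromatic substituent. Compound 3, `Cc1ccc([C@H](CCn2cncn2)Cc2ccccc2)cc1`, differs from compound 2 by phenyl in place of propyl on a saturated chain carbon, two bonds along the chain from an aromatic carbon. Among the compounds with values here, no measured step touches this part of the structure, so there is no direct guide. Compound 3 is therefore expected to show a step of a 1.3-fold lower number from compound 2 to compound 3 (0.10 log units; within the scatter) that stays within the scatter. For compound 3 the estimated value in this assay is 45 ug/mL, with a range from 18 ug/mL to 110 ug/mL.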

Compound 3, half-maximal cytotoxic concentration: 117 ug/mL
The estimate for compound 3 lay 2.6-fold (0.41 log units) below the measured number; the whole stated range lies below it.
By their numbers in this assay, from the lowest: compound 1; then compound 2; then compound 3.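

In this assay, this position on the saturated chain tolerates a change of group: phenyl in place of propyl gives a 2.1-fold higher number from compound 2 to compound 3 (0.32 log units; beyond the scatter), a modest step beyond the scatter. The methyl-bearing aromatic part stays the same across this step, so the chain position alone can move the number, in the same direction as a 3.0-fold higher number from compound 1 to compound 2 (0.48 log units; beyond the scatter). Nothing available bears on why the number moves here.

On these data alone, whether the aromatic ring or simply the larger group matters remains open. Cyclohexyl or a longer chain at this position would separate the two.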